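From Acetyl to Methylcarbamoyl in a Cytotoxicity Test

The source may hold more compounds than are shown below. What is called first, only, known or untested is meant among the compounds shown, and "the series" means these compounds.

In an ADME assay on J774 cells (Mus musculus) for cytotoxicity (on this read-out lower numbers stand for an effect already at smaller amounts and higher numbers for an effect only at larger amounts of compound), compound 1 `CCCCc1cc2c(=O)c(C(C)=O)c[nH]c2cc1OCCOc1ccccc1` is recorded as "not determined" (no result reported), so it offers no number of its own. Among the compounds with values here, the only other reading comes from compound 2 `O=c1cc[nH]c2cc(OCCOc3ccccc3)ccc12`, which gives > 20000 nM in this assay, and this is a limit of the assay and not a number. Compound 3 `CCCCc1cc2c(=O)c(C(=O)NC)c[nH]c2cc1OCCOc1ccccc1` has yet to be measured. The change leading to it is methylamino in place of methyl on a carbonyl carbon, with methylamino in place of methyl on a carbonyl carbon. No step beyond the usual scatter is expected from this change in this assay. For compound 3 the estimated value is 20000 nM, with an expected range from 8000 nM to 50000 nM.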

Compound 3, half-maximal effective concentration: > 20000 nM
Compound 3 ended at the assay's limit; the forecaster's own chance of this, stated with the estimate: 60%; the middle value lies on the limit itself.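

Compound 3 gives > 20000 nM in this assay, which is a limit of the assay and not a number. Within the data shown here, no step from compound 1 to compound 3 can be read. The compounds shown leave open at what concentration any cytotoxicity would begin.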